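This account rests on a few compounds, and the source may have more. Where it says the series, first, only, none or still open, it means among the compounds named here.

Measured so far in a functional assay on HL-60 cells (Homo sapiens) for cytotoxicity, read by MTT assay, with a stated time of 48 h; on this read-out lower numbers stand for stronger inhibition and higher numbers for weaker inhibition

compound 1 `COc1ccc(Nc2nc(-c3cccc(F)c3)nc3ccc(F)cc23)cc1` gives 38600 nM

compound 2 `Fc1cccc(-c2nc(Nc3ccc(Cl)cc3)c3cc(F)ccc3n2)c1` gives 45700 nM

Compound 2 sits level with compound 1, since the two numbers lie within the usual scatter of each other. Compound 3 `Fc1cccc(-c2nc(Nc3cccc(Br)c3)c3cc(F)ccc3n2)c1` keeps the shared core of compound 2 and carries 3-bromophenyl in place of 4-chlorophenyl on a nitrogen on an aromatic ring and it has not yet been measured. Going by the values given here, only one measured step bears on this change, a 1.2-fold higher number from compound 1 to compound 2 (0.07 log units; within the scatter) for chloro in place of methoxy on an aromatic carbon. Among the compounds with values here, it is a small step and a different swap, and no measured compound carries 3-bromophenyl, so the evidence is thin. The expected change is a 1.1-fold lower number from compound 2 to compound 3 (0.06 log units; within the scatter) in this assay and so no shift beyond the scatter is anticipated. For compound 3 the estimated value is 40000 nM with an expected range from 15000 nM to 90000 nM in this assay.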

Compound 3, half-maximal inhibitory concentration: > 50000 nM
Compound 3: no number, only a limit (the forecaster's own chance of this, stated with the estimate: 15%); middle value at least 1.2-fold (0.09 log units) away from the limit.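

In this assay compound 3 gives > 50000 nM, which is a limit of the assay and not a number. The step to it can therefore be read only as a floor, an at least 1.0-fold higher number from compound 2 to compound 3 (0.03 log units; that floor lies within the scatter), and likewise an at least 1.2-fold higher number from compound 1 to compound 3 (0.11 log units; that floor lies within the scatter); both floors lie within the scatter, so they neither show a real loss nor rule one out. With 4-methoxyphenyl, 4-chlorophenyl and 3-bromophenyl now tried on this nitrogen, no swap among these three compounds has given a step towards stronger inhibition beyond the scatter.

Compound 3 changes both the halogen and where it sits on the ring, so the compounds shown cannot separate those two changes. On these data alone, whether an amine or a carboxylic acid on this phenyl ring would give a lower number also stays open.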